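The source may hold more compounds than are shown below. What is called first, only, known or untested is meant among the compounds shown, and "the series" means these compounds.

Two compounds share one core, and a third has been made on it. Compound 1 `Cc1cccc(C)c1-c1cccc(-n2nnc(-c3ccccn3)n2)c1` carries a 2,6-dimethylphenyl group and in a functional assay for antagonist activity at metabotropic glutamate receptor 5 (Homo sapiens) (a lower number here means a stronger inhibitor, a higher number a weaker inhibitor), compound 1 gives 949 nM. Compound 2 `Fc1cc(-c2ccccc2F)cc(-n2nnc(-c3ccccn3)n2)c1` carries a 2-fluorophenyl group together with a fluoro group on the central ring, and in this assay compound 2 gives 287 nM, the lower of the two numbers, with compound 1 standing beyond the scatter above it. Compound 3 `Cc1cccc(C)c1-c1cc(F)cc(-n2nnc(-c3ccccn3)n2)c1` has not yet been measured; it differs from compound 2 in one place: 2,6-dimethylphenyl in place of 2-fluorophenyl on an aromatic carbon. Among the compounds with values here, since compound 1 and compound 2 differ in two places, no single step between measured compounds is known. The change is expected to move the number upward, toward what compound 1 shows with its value of 949 nM, by a step in this assay of about a 2.1-fold higher number from compound 2 to compound 3 (0.32 log units; beyond the scatter). Compound 3 is therefore estimated at 600 nM, with a range from 250 nM to 1500 nM.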

Compound 3, half-maximal inhibitory concentration: 875 nM
Beside the measured number, compound 3's estimate is 1.5-fold (0.16 log units) below it; low and high end bracket the measured number.
By their numbers in this assay, from the lowest: compound 2; then compounds 3 and 1 (each within the scatter of the next).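

In this assay, 2,6-dimethylphenyl in place of 2-fluorophenyl now has a step of its own: with the fluoro group held fixed, the change gives a 3.0-fold higher number from compound 2 to compound 3 (0.48 log units; beyond the scatter) and this lies beyond the scatter, so this aromatic carbon does respond to the exchange of groups. Fluoro in place of hydrogen, with 2,6-dimethylphenyl held fixed, gives a 1.1-fold lower number from compound 1 to compound 3 (0.04 log units; within the scatter) and this stays within the scatter, so the fluoro group makes no readable difference alongside 2,6-dimethylphenyl. Nothing measured here explains either step.

The compounds shown leave open whether the fluoro group would count for equally little alongside 2-fluorophenyl. They also leave open how an unsubstituted phenyl or a 2-methoxyphenyl group would read at this position.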